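The source may hold more compounds than are shown below. What is called first, only, known or untested is meant among the compounds shown, and "the series" means these compounds.

Measured in a functional assay on G-361 cells (Homo sapiens) for antiproliferative activity, with a stated time of 72 h; a higher number here means a weaker inhibitor, a lower number a stronger inhibitor:
- compound 1 `OC[C@H]1O[C@@H](n2cnc3c(NCc4cccc(F)c4)ncnc32)[C@H](O)[C@@H]1O`: > 166000 nM
- compound 2 `OC[C@H]1O[C@@H](n2cnc3c(NCc4ccc(Br)cc4)ncnc32)[C@H](O)[C@@H]1O`: > 166000 nM
- compound 3 `OC[C@H]1O[C@@H](n2cnc3c(NCc4ccc(F)c(F)c4F)ncnc32)[C@H](O)[C@@H]1O`: > 166000 nM

All three entries are limits, not numbers: the limit of > 166000 nM in this assay, at which 3 of the 3 values shown sit. Compound 3 therefore has no readable position in the series.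

Compound 4 `OC[C@H]1O[C@@H](n2cnc3c(NCc4cccc(O)c4O)ncnc32)[C@H](O)[C@@H]1O` carries this change: 2,3-dihydroxyphenyl in place of 2,3,4-trifluorophenyl on a saturated chain carbon bound to a nitrogen on an aromatic ring.

The measured steps bear on it only weakly: a step that the two limits leave unreadable from compound 1 to compound 2, a step that the two limits leave unreadable from compound 1 to compound 3 and a step that the two limits leave unreadable from compound 2 to compound 3. Going by the values given here, all three involve halogenated phenyl groups, and no compound with a hydroxy-bearing group has been measured. Compound 3 sits at the limit > 166000 nM, so any readable value would lie on the stronger side in this assay, and staying at the limit remains about as likely.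

The expected step is an at least 2.7-fold lower number from compound 3 to compound 4 (0.44 log units; beyond the scatter). For compound 4 the estimate is 60000 nM, with an expected range of 6000 nM to 166000 nM.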

Compound 4, half-maximal inhibitory concentration: 16900 nM
For compound 4 the middle estimate is 3.6-fold (0.55 log units) above the measured one; measured number inside the range.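

In this assay, placing 2,3-dihydroxyphenyl on a saturated chain carbon bound to a nitrogen on an aromatic ring, in place of the halogenated phenyl groups, gives an at least 9.8-fold lower number from compound 3 to compound 4 (0.99 log units; beyond the scatter), an at least 9.8-fold lower number from compound 2 to compound 4 (0.99 log units; beyond the scatter) and an at least 9.8-fold lower number from compound 1 to compound 4 (0.99 log units; beyond the scatter). These steps give only minimum sizes, as the other three entries remain limits: the limit of > 166000 nM in this assay, at which 3 of the 4 values shown sit. The steps among compound 1, compound 2 and compound 3 cannot be read, so the halogenated phenyl groups cannot be ranked.

As far as these compounds go, whether one hydroxy group would suffice stays open. So does the outcome with a methoxyphenyl or aminophenyl group at this place.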